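Swapping the aryl ring on sulfur in a benzamide series

The compounds below may be only part of what the source reports. "The series", "measured", "known", "first", "only" and "open" are said of these compounds alone.

Measured compounds:
Compound 1 `Nc1ccccc1NC(=O)c1ccc(CSc2ccc(Br)cc2)cc1`: 33.2%
Compound 2 `Cc1cc(C)cc(SCc2ccc(/C=C/C(=O)Nc3ccccc3N)cc2)c1`: 46.1%

In a functional assay on A549 cells (Homo sapiens) for inhibition, read by CCK-8 assay, with a stated time of 72 h, tested at 2 uM (on this read-out higher numbers stand for more inhibition of growth at the one concentration tested and lower numbers for less inhibition of growth), compound 1 gives 33.2%, the lower of the two numbers recorded, while compound 2 in this assay gives 46.1%, a gap that lies beyond the usual scatter. Among the compounds with values here, no single-point step between these two measured compounds is available; they differ in more than one place, so their two values are all that can be said of the pair.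

Compound 3 `Nc1ccccc1NC(=O)c1ccc(CSc2cccc(F)c2)cc1` is not yet measured. It differs from compound 1 in one place: 3-fluorophenyl in place of 4-bromophenyl on a sulfur. Both groups are of the same size, each a six-membered aromatic ring of carbon only carrying one halogen, and neither brings a donor or acceptor. Within the data shown here, with no measured step to go on, the expected change from compound 1 to compound 3 is a number 3.2 percentage points lower from compound 1 to compound 3 (within the scatter), that is, none beyond the scatter in either direction. Compound 3 is therefore estimated at 30%, with a range from 15% to 45%.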

Compound 3, percent growth inhibition at one concentration: 46.9%
Compound 3: the middle estimate sits 16.9 percentage points below what was measured; the measured number lies above the stated range.
By their numbers in this assay, from the lowest: compound 1; then compounds 2 and 3 (each within the scatter of the next).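

In this assay, the aryl group on the sulfur proves to matter: replacing 4-bromophenyl with 3-fluorophenyl gives a number 13.7 percentage points higher from compound 1 to compound 3 (beyond the scatter) even though the two groups have the same heavy-atom count, the same ring and the same zero count of hydrogen-bond donors and acceptors. Those shared counts therefore do not settle the read-out at this position, and a swap that leaves them unchanged can still move growth inhibition beyond the scatter. Nothing available accounts for this step.

The change replaces the halogen and alters its place on the ring in one move, so the compounds shown cannot say which of the two carries the step. As far as these compounds go, how plain phenyl or a pyridine ring on that sulfur would read in this assay also remains open.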